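The compounds below may be only part of what the source reports. "The series", "measured", "known", "first", "only" and "open" are said of these compounds alone.

Measured so far in a functional assay on the whole organism with Rattus norvegicus as the target; a higher number here means that more compound is needed for the effect, a lower number that less compound is needed:
- Compound 1 `Cc1cc(Cl)c(NC(=O)N(Cc2ccc(Oc3ccc(F)cc3)cc2)C2CCCCCC2)c(Cl)n1`: > 0.1 mg/kg, a limit
- Compound 2 `CSc1cc(C)nc(S(C)(=O)=O)c1NC(=O)N(Cc1ccc(Oc2ccc(F)cc2)cc1)C1CCCCCC1`: > 0.1 mg/kg, a limit

Compound 1 has no exact figure in this assay, and its > 0.1 mg/kg is a limit. Compound 2 is in the same position, with > 0.1 mg/kg also a limit. Going by the values given here, the record therefore amounts to the limit of > 0.1 mg/kg in this assay, at which 2 of the 2 values shown sit, and no pair of measured compounds yet gives a step in numbers.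

Compound 3 `Cc1cc(C)c(NC(=O)N(Cc2ccc(Oc3ccc(F)cc3)cc2)C2CCCCCC2)c(C)n1` departs from compound 1 in one place: a group of 9 heavy atoms (8 carbon, 1 nitrogen; one six-membered aromatic ring with 1 hetero atom) in place of a group of 9 heavy atoms (6 carbon, 1 nitrogen, 2 chlorine; one six-membered aromatic ring with 1 hetero atom), on an amide-type nitrogen. The chlorine-bearing group leaves, and 2,4,6-trimethylpyridin-3-yl enters on the same amide-type nitrogen.

Among the compounds with values here, with no measured step to go by, no change beyond the usual scatter is expected, and no direction can be favoured with confidence. The estimated step is a step that the limit leaves unreadable from compound 1 to compound 3. This expectation leans only on compound 1 and its limit of > 0.1 mg/kg, so it is a loose one. Compound 3 may itself return only a limit. For compound 3 the expected value is 0.2 mg/kg, with an estimated range from 0.04 mg/kg to 1 mg/kg.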

Compound 3, dose for half-maximal effect: 0.044 mg/kg
Compound 3: the middle estimate sits 4.5-fold (0.66 log units) above what was measured, and the stated range covers the measured number.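

In this assay, going by these compounds alone, replacing the chlorine-bearing group on the amide-type nitrogen with 2,4,6-trimethylpyridin-3-yl gives an at least 2.2-fold lower number from compound 1 to compound 3 (0.35 log units; beyond the scatter), the first step in numbers and one beyond the usual scatter. This shows that the result in this assay responds to the group at this place, even though both groups have 9 heavy atoms and one six-membered aromatic ring with 1 hetero atom, and differ in their atoms, with 8 carbon and 1 nitrogen entering where 6 carbon, 1 nitrogen and 2 chlorine leave. Compound 3 is also the only compound shown with an exact value, while the rest of the record consists of limits: the limit of > 0.1 mg/kg in this assay, at which 2 of the 3 values shown sit.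

On these data alone, whether the step needs both chlorine atoms to be exchanged remains open, as does how a ring carrying one chlorine and one methyl would compare in this assay. As far as these compounds go, it is equally open how larger or oxygen-bearing groups at the same places on the ring, such as ethyl or methoxy, would read against compound 3, and the data give no reason for the step itself.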